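The source may report more compounds than this note shows. Statements on the series, on what has been measured and on what is new or still open speak of the compounds shown alone.

Values measured in an ADME assay on HepG2 cells (Homo sapiens) for cytotoxicity, read by MTT assay, with a stated time of 72 h; a higher number here means a weaker inhibitor, a lower number a stronger inhibitor:

- compound 1 `Cc1ccc(S(=O)(=O)Cc2nc(Nc3ccccc3)c3ccccc3n2)cc1`: "nd(insoluble)" (no result reported)
- compound 2 `Cc1ccc(S(=O)(=O)Cc2nc(Nc3ccc(F)cc3)c3ccccc3n2)cc1`: > 15000 nM
- compound 3 `CC(C)=Cc1nc(Nc2ccccc2)c2cc([N+](=O)[O-])ccc2n1`: 50000 nM

Only compound 3 has a single number in this assay, at 50000 nM. For compound 2, > 15000 nM is a limit and not a number. Compound 1 has no result, so compound 3 cannot be ranked against either neighbour.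

Compound 4 `CC(C)=Cc1nc(Nc2cccc(Br)c2)c2cc([N+](=O)[O-])ccc2n1` keeps the frame of compound 3 but has bromo in place of hydrogen on an aromatic carbon, meta to a large group, turning phenyl into 3-bromophenyl (bromo in place of hydrogen on an aromatic carbon). Among the measured compounds shown here, no measured pair in this set differs in one place, so the size of this step has no direct precedent here. From compound 3 at 50000 nM, a small expected move toward a lower number in this assay seems most reasonable, and it may not clear the usual scatter. The expected step is a 1.7-fold lower number from compound 3 to compound 4 (0.22 log units; within the scatter). Compound 4 is estimated at 30000 nM, with an expected range from 10000 nM to 70000 nM.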

Compound 4, half-maximal inhibitory concentration: > 15000 nM
Compound 4: no number, only a limit; the forecaster's own chance of this, stated with the estimate: 25%; the middle value lies beyond the limit too.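

In this assay, compound 4 gives only a limit, so no step from compound 3 to compound 4 can be read, because the result stops at this limit: the limit of > 15000 nM in this assay, at which 2 of the 4 values shown sit.

The compounds shown leave open whether bromo in place of hydrogen on an aromatic carbon changes this read-out, and in which direction.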